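The compounds below may be only part of what the source reports. "The series", "measured", "known", "first", "only" and "open" are said of these compounds alone.

Measured compounds:
compound 1 `COC(=O)/C=C/c1cccc(N(Cc2ccc(/C=C/c3scnc3C)cc2)C(=O)C2CCCCC2)c1` gives 227 nM in an assay on isolated protein with Bile acid receptor (Homo sapiens) as the target; a lower number here means that less compound is needed, a higher number that more compound is needed for the effect;
compound 2 `COC(=O)/C=C/c1cccc(N(Cc2ccc(/C=C/c3scnc3C)cc2)C(=O)C(C)C)c1` gives 228 nM in this assay.

These two numbers lie within the scatter of each other, so compound 1 cannot be set apart from compound 2 on this read-out. Going by the values given here, the only measured step, a 1.0-fold higher number from compound 1 to compound 2 (0.00 log units; within the scatter), swaps the group on the carbonyl carbon and shows that this part of the molecule tolerates the exchange without a shift beyond the scatter.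

Compound 3 `COC(=O)/C=C/c1cccc(N(Cc2ccc(-c3ccc(F)c(Cl)c3)cc2)C(=O)C2CCCCC2)c1` is not yet measured. It differs from compound 1 at another position: 3-chloro-4-fluorophenyl in place of 2-(4-methyl-1,3-thiazol-5-yl)ethenyl on an aromatic carbon. Among the compounds with values here, no measured step touches this position, so the one step at hand does not bear on the change, and nothing in these data tells in which direction the number will move. The estimate for compound 3 is therefore kept near compound 1, with a wide range: 300 nM (from 60 nM to 1500 nM), a step of a 1.3-fold higher number from compound 1 to compound 3 (0.12 log units; within the scatter) expected from compound 1.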

Compound 3, half-maximal effective concentration: 66 nM
Compound 3: middle estimate off by 4.5-fold (0.66 log units), on the high side; the measured number falls inside the stated range.
By their numbers in this assay, from the lowest: compound 3; then compounds 1 and 2 (each within the scatter of the next).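

Going by these compounds alone, replacing the 2-(4-methyl-1,3-thiazol-5-yl)ethenyl group with 3-chloro-4-fluorophenyl gives a 3.4-fold lower number from compound 1 to compound 3 (0.54 log units; beyond the scatter) in this assay and is the first change here to move the number beyond the scatter. Within the data shown here, this position therefore responds to the group placed on it, unlike the carbonyl carbon, where the only step is a 1.0-fold higher number from compound 1 to compound 2 (0.00 log units; within the scatter). The entering group has neither the double bond nor the nitrogen and sulfur of the group it replaces, so compound 3 shows that none of these is needed for a low number at this position, and the data give no explanation for the shift.

From the compounds shown here alone, it remains open whether the chlorine, the fluorine or the plain phenyl ring accounts for the change, which an unsubstituted phenyl group could help to separate. Also open, going by these compounds, is how a carboxylic acid in place of the methyl ester would read with this new group in place.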